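This account rests on a few compounds, and the source may have more. Where it says the series, first, only, none or still open, it means among the compounds named here.

In an assay on HEK293 cells for positive allosteric modulation of metabotropic glutamate receptor 2 (Rattus norvegicus), read by thallium flux, with a stated time of 2.5 min (on this read-out lower numbers stand for an effect already at smaller amounts and higher numbers for an effect only at larger amounts of compound), compound 1, with structure `COc1cc(C(=O)O)ccc1OCCCCOc1ccc(C(=O)CC(C)C)c(O)c1C`, gives 40 nM. Compound 2, with structure `CCC(=O)c1ccc(OCCCCOc2cc(C(=O)O)ccc2OC)c(C)c1O`, gives 162 nM in this assay, and compound 3, with structure `COc1ccc(C(=O)O)cc1OCCCCOc1ccc(C(=O)C(C)C)c(O)c1C`, gives 116 nM. Compound 1 thus has the lowest of the three numbers, and its gaps to compound 3 and to compound 2 are both beyond the scatter. The cores of compound 1 and compound 2 differ in a way that is not broken down here.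

Compound 2 and compound 3 differ in one place only: methyl in place of hydrogen on a saturated chain carbon bound to a carbonyl carbon and a saturated chain carbon. In this assay that change made a 1.4-fold lower number from compound 2 to compound 3 (0.15 log units; within the scatter), so the two numbers are not told apart.

Compound 4, with structure `COc1cc(C(=O)O)ccc1OCCCCOc1ccc(C(=O)CC(C)(C)C)c(O)c1C`, has not yet been measured in this assay. It differs from compound 1 in one place: methyl in place of hydrogen on a saturated chain carbon bound to three saturated chain carbons. This is the same kind of change as that from compound 2 to compound 3, not the same one: there the added methyl sat on a saturated chain carbon bound to a carbonyl carbon and a saturated chain carbon, here it sits on a saturated chain carbon bound to three saturated chain carbons. Among the measured compounds shown here, the step from compound 1 to compound 4 is expected to be of the order of a 1.1-fold lower number from compound 1 to compound 4 (0.06 log units; within the scatter), because the one measured example of this kind of change, a 1.4-fold lower number from compound 2 to compound 3 (0.15 log units; within the scatter), stayed within the scatter. For compound 4 the expected value in this assay is therefore 35 nM, with a likely range from 15 nM to 90 nM.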

Compound 4, half-maximal effective concentration: 47 nM
The estimate for compound 4 lay 1.3-fold (0.13 log units) below the measured number; measured number inside the range.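

In this assay, the added methyl, which turns isobutyl into neopentyl, gave a 1.2-fold higher number from compound 1 to compound 4 (0.07 log units; within the scatter), so these two numbers cannot be told apart. This does not show that the methyl never matters on other cores. Among the compounds shown here, there are only two examples, the methyl sits at a different place in each, and the opposite directions of the two steps carry no meaning at this size, so neither step can be read as a real gain or loss. Within these limits, the change looks equally small on both cores, and nothing here suggests that the core alters its effect: the same change on two cores in this assay, a 1.4-fold lower number (0.15 log units; within the scatter) from compound 2 to compound 3 and a 1.2-fold higher number (0.07 log units; within the scatter) from compound 1 to compound 4, 1.6-fold (0.22 log units) apart, within the scatter of two such steps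

The compounds shown leave open how far this tolerance extends, since every change in this set stays among small branched saturated chains on the carbonyl, and a longer chain, a cyclohexyl ring or an amine in that place could behave quite differently. They also leave open what happens when the carboxylic acid, which all four compounds carry, is replaced by a group such as an amide or a tetrazole.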